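Dropping One Chloro: What to Expect for Compound 3

The source may report more compounds than this note shows. Statements on the series, on what has been measured and on what is new or still open speak of the compounds shown alone.

Measured so far in a functional assay on IGROV-1 cells (Homo sapiens) for cytotoxicity, read by sulforhodamine B assay, with a stated time of 48 h; on this read-out higher numbers stand for lower toxicity in this test and lower numbers for higher toxicity in this test:
compound 1, `ClCc1cccc(Cn2cnc3ncnc(Cl)c32)c1`: compound 1 gives 5880 nM
compound 2, `ClCc1ccc(Cn2cnc3nc(Cl)nc(Cl)c32)cc1`: compound 2 gives 5750 nM

On these two numbers compound 2 stands alongside compound 1; the two values differ only within the usual scatter of this kind of measurement, so neither can be called more or less toxic than the other.

Compound 3, `ClCc1ccc(Cn2cnc3ncnc(Cl)c32)cc1`, has not yet been measured in this assay. It differs from compound 2 in one place: hydrogen in place of chloro on an aromatic carbon that sits between two ring nitrogen atoms of the shared core. Within the data shown here, no step between two measured compounds shows what this change does. Compound 1 carries the same single-chloro core as compound 3 and gives a number close to that of compound 2, which suggests that the change should move the number little, in either direction, or not beyond the scatter. Compound 3 is therefore expected to give about 6500 nM, between 3000 nM and 14000 nM, an estimated step of a 1.1-fold higher number from compound 2 to compound 3 (0.05 log units; within the scatter).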

Compound 3, concentration lethal to 50% of the cells: > 100000 nM
Compound 3 ended at the assay's limit; the forecaster's own chance of this, stated with the estimate: 5%; at least 15-fold (1.18 log units) between middle value and limit.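

In this assay, replacing this one chloro with hydrogen gives an at least 17-fold higher number from compound 2 to compound 3 (1.24 log units; beyond the scatter), so the chloro on the aromatic carbon between two ring nitrogen atoms counts for much in the setting of compound 2, which the near-equal earlier values could not reveal. Compound 3 gives > 100000 nM, which is a limit of the assay and not a number, so the size of this step is a bound and not a measured distance: the limit of > 100000 nM in this assay, at which 1 of the 3 values shown sits. The core of compound 3 is shared by compound 1, and compound 1 gives 5880 nM, so hydrogen at this position does not by itself go with so high a number, and the change has to be read together with the rest of the molecule.

The compounds shown leave open whether an amine or a methoxy group on this same carbon would behave like the chloro of compound 2 or like the hydrogen of compound 3. They also leave open how far past the limit compound 3 truly lies, and what a chloro at this position would do on the scaffold of compound 1.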